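A Benzyl Ester Traded for a Methyl Ester

This account rests on a few compounds, and the source may have more. Where it says the series, first, only, none or still open, it means among the compounds named here.

Two sugar-derived azido esters have been examined in an ADME assay on A549 cells (Homo sapiens) for cytotoxicity, read by MTT assay, with a stated time of 24 h, tested at 2 ug/mL; on this read-out higher numbers stand for a weaker effect at the one concentration tested and lower numbers for a stronger effect. Compound 1, `CO[C@H]1O[C@@H]([C@@H](N=[N+]=[N-])C(=O)OCc2ccccc2)[C@@H](OCc2ccccc2)[C@@]2(OCc3ccccc3)[C@@H](OCc3ccccc3)CO[C@@H]12`, gives 76.2%. Compound 2, `CC(=O)Nc1nc(Cl)c2c(ncn2[C@@H]2O[C@@H]([C@H](N=[N+]=[N-])C(=O)OCc3ccccc3)[C@@H](OCc3ccccc3)[C@@]3(OCc4ccccc4)[C@@H](OCc4ccccc4)CO[C@@H]23)n1`, gives 82.2% in this assay, which places it at the top of the two numbers, yet its gap to compound 1 lies within the scatter, so no real ranking follows. Compound 3, `COC(=O)[C@@H](N=[N+]=[N-])[C@@H]1O[C@@H](n2cnc3nc(NC(C)=O)nc(Cl)c32)[C@@H]2OC[C@H](OCc3ccccc3)[C@]2(OCc2ccccc2)[C@@H]1OCc1ccccc1`, remains to be measured. It differs from compound 2 in one place: hydrogen in place of phenyl on a saturated chain carbon bound to an oxygen next to a carbonyl group, that is, benzyloxycarbonyl becomes methoxycarbonyl. For the measured compounds named here, no step between measured compounds is available to gauge such a change, so the expectation rests on compound 2 alone. Because compound 2 gives 82.2%, a weak effect is expected to persist, and the step of a number 2.2 percentage points lower from compound 2 to compound 3 (within the scatter) is estimated to stay within the scatter in either direction. Compound 3 is therefore expected to give about 80% in this assay, within a range from 65% to 93%.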

Compound 3, a percentage reported as activity, at one concentration (the size of the read-out at that concentration, not a potency): 77.7%
Compound 3: the middle estimate sits 2.3 percentage points above what was measured; low and high end bracket the measured number.
By their numbers in this assay, from the lowest: compounds 1, 3 and 2 (each within the scatter of the next).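

For the compounds shown here, compound 3 gives the first measured step at this position: in this assay, the exchange of benzyloxycarbonyl for methoxycarbonyl is a number 4.5 percentage points lower from compound 2 to compound 3 (within the scatter). The phenyl on the saturated chain carbon bound to an oxygen next to a carbonyl group can therefore be replaced by hydrogen without a step beyond the scatter at the one concentration tested. This holds for this single pair only, and nothing available bears on why the result takes this form.

The compounds shown leave open how a longer chain on the ester oxygen, or a carboxylic acid or an amide in place of the ester, would read out in this assay. They also leave open whether the benzyl and methyl esters would remain within the scatter of each other at other concentrations.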